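A few compounds are considered here, and "the series" means these few. Any claim that something is new, unique, unknown or untested is made for them only; others in the source may bear on it.

Working notes on the series. In a functional assay on RS4-11 cells (Homo sapiens) for inhibition, read by CCK-8 assay, with a stated time of 48 h, tested at 20 uM (a higher number here means more inhibition of growth at the concentration tested, a lower number less inhibition of growth), compound 1 `COc1ccc(Cc2nnc(NC(=O)/C(C#N)=C/c3ccccc3OS(=O)(=O)c3ccc([N+](=O)[O-])cc3)s2)cc1` gives 70%, compound 2 `COc1ccc(Cc2nnc(NC(=O)/C(C#N)=C/c3ccccc3OS(=O)(=O)c3ccccc3[N+](=O)[O-])s2)cc1` gives 68% and compound 3 `COc1ccc(Cc2nnc(NC(=O)/C(C#N)=C/c3ccccc3OS(=O)(=O)c3ccc(Cl)cc3)s2)cc1` gives 79%. These three compounds differ only in the aryl group on the sulfonyl sulfur. The measured steps are a number 2 percentage points lower from compound 1 to compound 2 (within the scatter), a number 9 percentage points higher from compound 1 to compound 3 (within the scatter) and a number 11 percentage points higher from compound 2 to compound 3 (beyond the scatter). Compound 3 thus stands level with compound 1 within the scatter and modestly clear of compound 2.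

Compound 4 `N#C/C(=C\c1ccccc1OS(=O)(=O)c1ccc(Cl)cc1)C(=O)Nc1nnc(Cc2cccc3ccccc23)s1` keeps the 4-chlorophenyl on the sulfonyl sulfur of compound 3 and changes a different place: naphthalen-1-yl in place of 4-methoxyphenyl on a saturated chain carbon bound to an aromatic carbon. In words, naphthalen-1-yl replaces 4-methoxyphenyl on a saturated chain carbon bound to an aromatic carbon. Going by the values given here, no measured step touches this place, so the three steps bear on it only indirectly. They show how far this assay has moved within this small set, and the largest of them is the modest a number 11 percentage points higher from compound 2 to compound 3 (beyond the scatter). The data hold no direct evidence on the direction of the new change, so no step beyond the scatter is expected, though the uncertainty is wide.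

The expected change is a number 4 percentage points lower from compound 3 to compound 4 (within the scatter).

For compound 4 the estimated value is 75%, with an expected range of 58% to 90%.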

Compound 4, percent growth inhibition at one concentration: 68%
Compound 4: the middle estimate sits 7 percentage points above what was measured; low and high end bracket the measured number.
By their numbers in this assay, from the lowest: compounds 2, 4, 1 and 3 (each within the scatter of the next, the first and the last beyond it).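

Going by these compounds alone, the place on a saturated chain carbon bound to an aromatic carbon, untouched by the earlier steps, is not silent in this assay: a number 11 percentage points lower from compound 3 to compound 4 (beyond the scatter). This modest step is of the same printed size as the largest among the sulfonyl aryl changes, a number 11 percentage points higher from compound 2 to compound 3 (beyond the scatter), so this place can move the read-out as far as the sulfonyl aryl group has here. The bicyclic group is still accommodated, with compound 4 giving 68%, but the swap from 4-methoxyphenyl to naphthalen-1-yl changes several counted features at once, going from 8 to 10 heavy atoms, from one six-membered aromatic ring to 2, and from 1 hydrogen-bond acceptor to 0.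

No measured information on the compounds accounts for this step.

The pair leaves open whether the step follows the loss of the methoxy oxygen or the added ring, a question that unsubstituted phenyl, 4-hydroxyphenyl or naphthalen-2-yl at this place would help to separate. It also leaves open whether the step holds with 4-nitrophenyl or 2-nitrophenyl on the sulfonyl sulfur in place of 4-chlorophenyl.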